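Amino in place of bromo at the assay limit

The source may report more compounds than this note shows. Statements on the series, on what has been measured and on what is new or still open speak of the compounds shown alone.

Measured so far:
compound 1 `Fc1cccc(-c2nc(Nc3cccc(Cl)c3)c3cc(F)ccc3n2)c1` gives > 50000 nM
compound 2 `Fc1cccc(-c2nc(Nc3ccccc3Cl)c3cc(F)ccc3n2)c1` gives > 50000 nM
compound 3 `Fc1cccc(-c2nc(Nc3ccc(Br)cc3)c3cc(F)ccc3n2)c1` gives > 50000 nM

In a functional assay on MCF7 cells (Homo sapiens) for cytotoxicity, read by MTT assay, with a stated time of 48 h (a lower number here means a stronger inhibitor, a higher number a weaker inhibitor), compound 3 gives only a limit (> 50000 nM) and no number. All three compounds sit at the limit of > 50000 nM in this assay, at which 3 of the 3 values shown sit, and cannot be ranked against one another.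

Compound 4 `Nc1ccc(Nc2nc(-c3cccc(F)c3)nc3ccc(F)cc23)cc1` differs from compound 3 in one place: amino in place of bromo on an aromatic carbon (amino in place of bromo on an aromatic carbon, para to a large group). The measured steps that bear on this change are a step that the two limits leave unreadable from compound 1 to compound 2 and a step that the two limits leave unreadable from compound 1 to compound 3 and a step that the two limits leave unreadable from compound 2 to compound 3 with no readable size among them. All three exchange one halogenated phenyl for another, and none brings in an amino group, so they set no size for this change.

Only a modest step toward a stronger inhibitor can be expected, and with little support. In this assay the expected size is an at least 1.6-fold lower number from compound 3 to compound 4 (0.22 log units; that floor lies within the scatter) with a real chance of no readable change. The estimate for compound 4 is 30000 nM within an expected range of 8000 nM to 80000 nM and a further limit remains quite possible.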

Compound 4, half-maximal inhibitory concentration: > 50000 nM
Compound 4: only a limit was reported; the forecaster's own chance of this, stated with the estimate: 55%; middle value at least 1.6-fold (0.22 log units) from the limit.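

Among the compounds shown here, compound 4 joins compound 1, compound 2 and compound 3 at one shared limit in this assay and so no new step to compound 4 can be read: the limit of > 50000 nM in this assay, at which 4 of the 4 values shown sit.

Still open, from the compounds shown here alone, is whether any change to the shared core gives a number rather than a limit in this assay for this series.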